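The compounds below may be only part of what the source reports. "The series", "measured", "known", "first", "only" and "open" are said of these compounds alone.

The measured compounds and their numbers in a functional assay on DU-145 cells (Homo sapiens) for inhibition, read by trypan blue exclusion, with a stated time of 96 h; on this read-out higher numbers stand for weaker inhibition of growth and lower numbers for stronger inhibition of growth:
compound 1, `COc1ccc(/C=C(/SCc2ccc(Cl)cc2)C(=O)c2ccc(Cl)cc2)cc1`: 10000 nM
compound 2, `COc1ccc(/C=C(/Sc2ccc(Br)cc2)C(=O)c2ccc(Cl)cc2)cc1`: 50000 nM
compound 3, `COc1ccc(/C=C(/Sc2ccc(C)cc2)C(=O)c2ccc(Cl)cc2)cc1`: 1000 nM

Among these three numbers compound 1 stands second highest. Its nearest neighbour is compound 2, a 5.0-fold higher number from compound 1 to compound 2 (0.70 log units; beyond the scatter); the furthest is compound 3, a 10-fold lower number from compound 1 to compound 3 (1.00 log units; beyond the scatter). Between the other two, a 50-fold lower number from compound 2 to compound 3 (1.70 log units; beyond the scatter).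

Compound 4, `Cc1cc(C)cc(/C=C(/SCc2ccc(Cl)cc2)C(=O)c2ccc(Cl)cc2)c1`, has not yet been measured in this assay. It differs from compound 1 in one place: 3,5-dimethylphenyl in place of 4-methoxyphenyl on a double-bonded chain carbon bound to a double-bonded chain carbon. Every one of the three measured steps alters the group carried on the sulfur, and all three leave the 4-methoxyphenyl on the double-bonded chain carbon untouched. Two of those steps were modest and one was large, which shows that this assay does respond to a change at a single position of the shared core, but the data hold nothing about an exchange of the 4-methoxyphenyl itself. For the measured compounds named here, no measured step bears directly on the step from compound 1 to compound 4, so its direction cannot be read from the numbers, and a movement either way, or none beyond the scatter, is open. Compound 4 is therefore estimated at 10000 nM, within 2000 nM to 50000 nM, an expected step of no change at the digits printed from compound 1 to compound 4 (within the scatter).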

Compound 4, concentration for 50% growth inhibition: 10000 nM
For compound 4 middle estimate and measured number coincide at the digits printed; low and high end bracket the measured number.
By their numbers in this assay, from the lowest: compound 3; then compounds 1 and 4 (each within the scatter of the next); then compound 2.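

In this assay, for the compounds shown here, the exchange of 4-methoxyphenyl for 3,5-dimethylphenyl gives no change at the digits printed from compound 1 to compound 4 (within the scatter), the first reading at this position, since every earlier step altered the group on the sulfur, among them a 50-fold lower number from compound 2 to compound 3 (1.70 log units; beyond the scatter). With 4-chlorobenzyl on the sulfur, the entering group carries no oxygen and no hydrogen-bond acceptor, so on this read-out neither feature of 4-methoxyphenyl is needed to keep growth inhibition at the level of compound 1, and this exchange is tolerated where the changes on the sulfur were not. No available evidence accounts for this result.

Going by these compounds alone, whether the exchange would be tolerated in the same way with 4-methylphenyl on the sulfur, the group of compound 3, remains open, as the one step at this position was taken with 4-chlorobenzyl there. Going by these compounds, it is also open how the assay would respond to a phenyl ring bearing a dimethylamino group, a carboxylic acid or a longer alkyl chain at this place.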